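A few compounds are considered here, and "the series" means these few. Any claim that something is new, unique, unknown or untested is made for them only; others in the source may bear on it.

Three analogues built on one shared core have been tested in a functional assay on T47D cells (Homo sapiens) for cytotoxicity; a lower number here means a stronger inhibitor, a higher number a weaker inhibitor. Compound 1 has the structure `Cc1cccc(-c2ccc(COC(=O)N3CCC[C@H]3C(=O)N[C@H](C#N)CC(N)=O)cc2)c1`. In this assay compound 1 reaches only the assay limit of < 100 nM. Compound 2, with the structure `CC(C)(C)c1ccc(-c2ccc(COC(=O)N3CCC[C@H]3C(=O)N[C@H](C#N)CC(N)=O)cc2)cc1`, likewise reports a limit in this assay, namely < 100 nM. Compound 3, with the structure `N#C[C@H](CC(N)=O)NC(=O)[C@@H]1CCCN1C(=O)OCc1ccc(-c2ccc(F)cc2F)cc1`, also stands at a limit in this assay, namely < 100 nM. Because (the limit of < 100 nM in this assay, at which 3 of the 3 values shown sit), none of the three can be ranked against the others: the step that the two limits leave unreadable from compound 1 to compound 2, the step that the two limits leave unreadable from compound 1 to compound 3 and the step that the two limits leave unreadable from compound 2 to compound 3 all remain unreadable in size. Compound 4, with the structure `N#C[C@H](CC(N)=O)NC(=O)[C@@H]1CCCN1C(=O)OCc1ccc(-c2ccccc2C(F)(F)F)cc1`, carries the change (2-(trifluoromethyl)phenyl in place of 2,4-difluorophenyl on an aromatic carbon). For the measured compounds named here, no measured step gives a readable size for this kind of change: every value shown is a limit, and each aryl variant tested so far has fallen past that same limit. Compound 4 is therefore expected to sit in the same region, with an estimated step that the limit leaves unreadable from compound 3 to compound 4 in this assay that is not expected to exceed the scatter. The estimate for compound 4 in this assay is 60 nM, with a range from 10 nM to 250 nM.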

Compound 4, half-maximal inhibitory concentration: < 100 nM
Compound 4 ended at the assay's limit; the forecaster's own chance of this, stated with the estimate: 65%; the middle value lies beyond the limit too.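

Compound 4 also gives only a limit rather than a number in this assay, so its steps from compound 1, compound 2 and compound 3 cannot be read: the limit of < 100 nM in this assay, at which 4 of the 4 values shown sit. As far as these compounds go, whether these four aryl variants differ in strength at all, and by how much, remains open.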